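Swapping Trifluoromethoxy for Sulfamoyl

The compounds below may be only part of what the source reports. "The series", "measured", "known", "first", "only" and "open" are said of these compounds alone.

In a functional assay for inhibition, with Rattus norvegicus as the target (a lower number here means a stronger inhibitor, a higher number a weaker inhibitor), compound 1 `CC(/N=c1\c(O)c(O)\c1=N/c1ccccc1)C(C)(C)C` gives 5400 nM. Compound 2 `CC(/N=c1\c(O)c(O)\c1=N/c1ccc(OC(F)(F)F)cc1)C(C)(C)C` carries a trifluoromethoxy group where compound 1 has hydrogen on an aromatic carbon. Compound 2 reaches only a limit of this assay, not a number: > 30000 nM. Among the measured compounds shown here, the single measured step at this place is an at least 5.5-fold higher number from compound 1 to compound 2 (0.74 log units; beyond the scatter), so the change took the series toward a weaker inhibitor.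

Compound 3 `CC(/N=c1\c(O)c(O)\c1=N/c1ccc(S(N)(=O)=O)cc1)C(C)(C)C` keeps the shared core and exchanges that same group, with sulfamoyl in place of trifluoromethoxy on an aromatic carbon. For the measured compounds named here, no measurement yet shows what sulfamoyl does here, so the best guide is compound 1 at 5400 nM, the one reading at this place that is a true number. The trifluoromethoxy group is gone, so part of the measured step may be undone, although compound 3 could still end at the limit of this assay. A step of an at least 3.7-fold lower number from compound 2 to compound 3 (0.57 log units; beyond the scatter) is expected, toward a lower number and so a stronger inhibitor. For compound 3 the estimated value is 8000 nM, with an expected range from 1500 nM to 30000 nM.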

Compound 3, half-maximal inhibitory concentration: > 30000 nM
Compound 3: a limit, no number (the forecaster's own chance of this, stated with the estimate: 30%); middle value at least 3.7-fold (0.57 log units) from the limit.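

Placing sulfamoyl on this aromatic carbon, where compound 1 has hydrogen, gives an at least 5.5-fold higher number from compound 1 to compound 3 (0.74 log units; beyond the scatter) in this assay. The weakening seen with trifluoromethoxy therefore also appears with a second group, even though sulfamoyl brings a hydrogen-bond donor and trifluoromethoxy has none, so among the three compounds shown, both substituents on this carbon go with a weaker inhibitor than hydrogen does. Compound 2 and compound 3 both stop at a limit rather than a number, so the step between them cannot be read and neither group can be ranked against the other: the limit of > 30000 nM in this assay, at which 2 of the 3 values shown sit.

Still open, from the compounds shown here alone, is whether any group at this place can match or beat the hydrogen of compound 1, for example a fluorine atom, a methyl group, an amine or a carboxylic acid. Going by these compounds, the true size of the loss also stays unknown, as compound 1 is the only one of the three with a real number in this assay.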